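Fluoroanilides on a shared bromoquinolinone core

The compounds below may be only part of what the source reports. "The series", "measured", "known", "first", "only" and "open" are said of these compounds alone.

Three amides built on the same core have been tested so far. Compound 1 `O=C(Nc1ccc(F)cc1F)c1cc(=O)[nH]c2cc(Br)ccc12` carries two fluoro groups on its aniline ring. In a functional assay on KYSE-410 cells (Homo sapiens) for antiproliferative activity, read by MTT assay, with a stated time of 72 h (a lower number here means a stronger inhibitor, a higher number a weaker inhibitor), compound 1 gives only a limit, > 20000 nM, not a number. Compound 2 `O=C(Nc1ccc(F)cc1)c1cc(=O)[nH]c2cc(Br)ccc12` has one fluoro group. In this assay compound 2 likewise reaches only the limit of > 20000 nM. Compound 3 `O=C(Nc1cc(F)ccc1F)c1cc(=O)[nH]c2cc(Br)ccc12` again carries two fluoro groups, arranged differently from compound 1; the difference between the two cores is not broken down here. In this assay compound 3 also stops at the limit, > 20000 nM.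

The change from compound 1 to compound 2 is hydrogen in place of fluoro on an aromatic carbon. Its size is unreadable, a step that the two limits leave unreadable from compound 1 to compound 2, because both ends sit at the limit of > 20000 nM in this assay, at which 3 of the 3 values shown sit.

Compound 4 `O=C(Nc1cccc(F)c1)c1cc(=O)[nH]c2cc(Br)ccc12` has not yet been measured. It differs from compound 3 by hydrogen in place of fluoro on an aromatic carbon. This is the same kind of change as that from compound 1 to compound 2, though the surroundings differ: in the earlier pair the place was meta to a fluoro group, here it is para to a fluoro group.

Since compound 3 sits at the limit > 20000 nM, the step from compound 3 to compound 4 is expected to be about a step that the limit leaves unreadable from compound 3 to compound 4. Compound 4 is therefore expected to give roughly 30000 nM, most likely reported again as a limit, with a range from 8000 nM to 100000 nM.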

Compound 4, half-maximal inhibitory concentration: 7300 nM
For compound 4 the middle estimate is 4.1-fold (0.61 log units) above the measured one; the measured number lies below the stated range.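

In this assay, hydrogen in place of fluoro on an aromatic carbon, at the place para to a fluoro group, gives an at least 2.7-fold lower number from compound 3 to compound 4 (0.43 log units; beyond the scatter), so on this ring the change goes with a lower number and a stronger inhibitor. Exchanging 4-fluorophenyl for 3-fluorophenyl on the amide-type nitrogen gives an at least 2.7-fold lower number from compound 2 to compound 4 (0.43 log units; beyond the scatter), which shows that compound 4 stands apart from both of its neighbours, yet each of these steps is known only as a minimum size. The same kind of change from compound 1 to compound 2 cannot be read, like every other step with both ends at a limit, so the series does not show whether the change carries its effect from one set of surroundings to another: the limit of > 20000 nM in this assay, at which 3 of the 4 values shown sit.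

From the compounds shown here alone, what stays open is how the number would move with a chloro group, a methoxy group or an amine at the place the fluoro group holds in compound 4, or with no fluoro group on the aniline ring at all. Going by these compounds, it is also open whether the same step would appear on a core other than the shared one.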